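A Second Chloro on the Phenol Ring

A few compounds are considered here, and "the series" means these few. Any claim that something is new, unique, unknown or untested is made for them only; others in the source may bear on it.

Measured so far in a functional assay on BGC-823 cells (Homo sapiens) for cytotoxicity, read by MTT assay, with a stated time of 48 h; a lower number here means a stronger inhibitor, a higher number a weaker inhibitor:
compound 1 `O=C(CSc1nnc(-c2ccncc2)o1)N/N=C/c1ccc(F)cc1` gives 17800 nM
compound 2 `O=C(CSc1nnc(-c2ccncc2)o1)N/N=C/c1ccccc1F` gives 24000 nM
compound 3 `O=C(CSc1nnc(-c2ccncc2)o1)N/N=C/c1cc(Cl)ccc1O` gives 5470 nM

All three share the same core and differ only in the aryl group attached to the carbon that carries a double bond to nitrogen. Compound 3 gives the lowest number of the three, and both gaps separating it from the others lie beyond the scatter: a 3.3-fold lower number from compound 1 to compound 3 (0.51 log units; beyond the scatter) and a 4.4-fold lower number from compound 2 to compound 3 (0.64 log units; beyond the scatter). Between the two fluorophenyl compounds themselves the step is small, a 1.3-fold higher number from compound 1 to compound 2 (0.13 log units; within the scatter).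

Compound 4 `O=C(CSc1nnc(-c2ccncc2)o1)N/N=C/c1cc(Cl)cc(Cl)c1O` is the next step from compound 3. The change is chloro in place of hydrogen on an aromatic carbon, ortho to the hydroxy group and meta to the chloro group already present, so the ring reads 3,5-dichloro-2-hydroxyphenyl instead of 5-chloro-2-hydroxyphenyl.

Going by the values given here, none of the measured steps adds a second halogen to an aryl ring that already carries one; the steps into compound 3 exchanged the whole substitution pattern at once. Among the compounds with values here, there is therefore no measured precedent for the size of this step in this assay, and the expected step is a 1.4-fold lower number from compound 3 to compound 4 (0.14 log units; within the scatter), a change not clearly beyond the scatter. Compound 4 is estimated at 4000 nM, within a range from 1500 nM to 12000 nM.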

Compound 4, half-maximal inhibitory concentration: 6340 nM
The estimate for compound 4 lay 1.6-fold (0.20 log units) below the measured number; measured number inside the range.
By their numbers in this assay, from the lowest: compounds 3 and 4 (each within the scatter of the next); then compounds 1 and 2 (each within the scatter of the next).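

In this assay, putting chloro in place of hydrogen on the aromatic carbon ortho to the hydroxy group and meta to the chloro group gives a 1.2-fold higher number from compound 3 to compound 4 (0.06 log units; within the scatter), so a second halogen on this ring leaves the number effectively unchanged, something the earlier whole-ring exchanges could not show. The gap to the fluorophenyl compounds also survives the added chloro, with a 3.8-fold lower number from compound 2 to compound 4 (0.58 log units; beyond the scatter) and a 2.8-fold lower number from compound 1 to compound 4 (0.45 log units; beyond the scatter), so the 3,5-dichloro-2-hydroxyphenyl ring stays on the same side of those two compounds as the 5-chloro-2-hydroxyphenyl ring. Nothing available here explains why this added chloro makes so little difference in this assay.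

The four compounds do not separate the part played by the hydroxy group from that of the chloro groups, since both rings with the lower numbers carry both kinds of group and neither fluorophenyl ring carries a hydroxy group. On these data alone, it also stays open whether a larger or different group at the same ring position, such as bromo, methoxy or an amine, would shift the number any more than chloro does.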